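The source may report more compounds than this note shows. Statements on the series, on what has been measured and on what is new or still open speak of the compounds shown alone.

Compound 1 `CCn1c(SCC(=O)c2ccccc2)nnc1-c1ccc(OC)cc1` stands highest of the two numbers in a functional assay on the whole organism (strain albino) for inhibition, with Rattus norvegicus as the target, read by paw edema, with a stated time of 5 h, at a dose of 0.28 mmol/kg by the oral route (a lower number here means less inhibition, a higher number more inhibition at the dose given (going by the name of the read-out)), where compound 1 gives 61%. Its nearest neighbour is compound 2 `CCn1c(SCC(=O)c2ccccc2)nnc1-c1ccccc1`, which in this assay gives 51%. The step between them is a number 10 percentage points lower from compound 1 to compound 2 (within the scatter). Compound 3 `C=CCn1c(SCC(=O)c2ccccc2)nnc1-c1ccc(OC)cc1` differs from compound 1 by vinyl in place of methyl on a saturated chain carbon bound to an aromatic nitrogen. Going by the values given here, the single measured step concerns the methoxy group and says nothing about a change at the saturated chain carbon bound to the aromatic nitrogen, so no step beyond the scatter is expected; the estimated step is a number 1 percentage points lower from compound 1 to compound 3 (within the scatter). Compound 3 is therefore expected to give 60% in this assay, estimated between 42% and 76%.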

Compound 3, a percentage reported as inhibition, in the whole organism at one dose (the size of the read-out at that dose, not a potency): 61%
Compound 3: middle estimate off by 1 percentage points, on the low side; low and high end bracket the measured number.
By their numbers in this assay, from the lowest: compounds 2, 1 and 3 (each within the scatter of the next).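

In this assay, vinyl in place of methyl on the saturated chain carbon bound to the aromatic nitrogen, which reads as ethyl to allyl one bond further out, gives no change at the digits printed from compound 1 to compound 3 (within the scatter) at this position. Going by these compounds alone, the earlier compounds varied only the methoxy group, so this is the first sign that this chain accepts a double bond without a step beyond the scatter. No evidence at hand explains this result. From the compounds shown here alone, whether a longer chain, a benzyl group or a chain ending in an amine would behave the same stays open. So does whether allyl would give the same result on compound 2.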